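The source may hold more compounds than are shown below. What is called first, only, known or untested is meant among the compounds shown, and "the series" means these compounds.

Measured so far: compound 1, `O=C(O)/C=C/C(=O)c1ccccc1`, gives 30600 nM in a functional assay on HeLa cells (Homo sapiens) for inhibition, read by MTT assay, with a stated time of 72 h; on this read-out lower numbers stand for stronger inhibition and higher numbers for weaker inhibition; compound 2, `CC(C)c1cc(C(C)C)c(C(=O)/C=C/C(=O)O)c(C(C)C)c1`, gives 6100 nM.

Compound 1 stands at the highest number of the two, and the gap to compound 2 lies beyond the scatter. Compound 3, `O=C(O)/C=C/C(=O)c1ccc(Br)cc1`, is not yet measured; it differs from compound 1 by bromo in place of hydrogen on an aromatic carbon. Among the compounds with values here, with no measured pair showing this change, the expected step of a 2.0-fold lower number from compound 1 to compound 3 (0.31 log units; beyond the scatter) is a small move toward a lower number, one that may well stay within the scatter. Compound 3 is therefore estimated at 15000 nM, with a range from 5000 nM to 45000 nM.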

Compound 3, half-maximal inhibitory concentration: 18700 nM
For compound 3 the middle estimate is 1.2-fold (0.10 log units) below the measured one, and the stated range covers the measured number.
By their numbers in this assay, from the lowest: compound 2; then compounds 3 and 1 (each within the scatter of the next).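

In this assay, bromo in place of hydrogen on an aromatic carbon, para to a group of 7 heavy atoms, gives a 1.6-fold lower number from compound 1 to compound 3 (0.21 log units; within the scatter) and so leaves the number within the scatter. Within the data shown here, this is the first single change on the core of compound 1 that can be read as a step, and at this position bromo shows no clear effect. No measurement at hand bears on this result. Going by these compounds, what an amine or a methoxy group at this same place would give remains open.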